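The source may hold more compounds than are shown below. What is called first, only, known or untested is meant among the compounds shown, and "the series" means these compounds.

Series notes. Compound 1 `Brc1cn2ccnc2c(-c2ccc3ncn(C4CCCCC4)c3c2)n1` and compound 2 `CC(=O)c1ccc(-c2cn3ccnc3c(-c3ccc4ncn(C5CCCCC5)c4c3)n2)cc1` share one core and differ at a single aromatic carbon. In a functional assay on PC-3 cells (Homo sapiens) for inhibition, read by sulforhodamine B assay, with a stated time of 48 h, tested at 10 uM (a lower number here means less inhibition, a higher number more inhibition at the concentration tested (going by the name of the read-out)), compound 1 gives 17.2%, and compound 2 gives 17.9%. The step of a number 0.7 percentage points higher from compound 1 to compound 2 (within the scatter) is within the scatter, so these two numbers cannot be ordered. On the numbers shown, compound 2 stands highest of two, with compound 1 within the scatter of it.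

Compound 3 `Fc1ccccc1-c1cn2ccnc2c(-c2ccc3ncn(C4CCCCC4)c3c2)n1` has not been measured in this assay. It differs from compound 2 as follows: 2-fluorophenyl in place of 4-acetylphenyl on an aromatic carbon. For the measured compounds named here, the only measured step bearing on this position is a number 0.7 percentage points higher from compound 1 to compound 2 (within the scatter), where exchanging bromo for 4-acetylphenyl left the read-out within the scatter. A second six-membered aromatic ring of carbon only, 2-fluorophenyl, is therefore expected to behave alike, and a number 0.9 percentage points lower from compound 2 to compound 3 (within the scatter) is expected to be no step beyond the scatter. Compound 3 is estimated at 17% in this assay, with a range from 5% to 32%.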

Compound 3, a percentage reported as inhibition, at one concentration (the size of the read-out at that concentration, not a potency): 32.6%
For compound 3 the middle estimate is 15.6 percentage points below the measured one; the whole stated range lies below it.
By their numbers in this assay, from the lowest: compounds 1 and 2 (each within the scatter of the next); then compound 3.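

In this assay, replacing 4-acetylphenyl with 2-fluorophenyl gives a number 14.7 percentage points higher from compound 2 to compound 3 (beyond the scatter), and replacing bromo with 2-fluorophenyl gives a number 15.4 percentage points higher from compound 1 to compound 3 (beyond the scatter). The read-out therefore does respond to the group on this aromatic carbon, and 4-acetylphenyl and 2-fluorophenyl are not interchangeable here, although each carries one six-membered aromatic ring of carbon only. Nothing at hand accounts for this difference.

The compounds shown leave open whether the higher number goes with the fluorine, with its place on the ring, or with the loss of the acetyl group. Plain phenyl and 4-fluorophenyl would separate these readings, and how a phenyl ring bearing an amine or a carboxylic acid would behave at this carbon also remains open.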